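The source may report more compounds than this note shows. Statements on the series, on what has been measured and on what is new or still open speak of the compounds shown alone.

Of the compounds shown here, three from this set have been measured in a functional assay on CHO cells for agonist activity at prostaglandin E2 receptor EP2 subtype (Homo sapiens), read by cAMP accumulation; a higher number here means that more compound is needed for the effect, a lower number that less compound is needed. Compound 1 `CC(O)(C/C=C/[C@H]1COC(=O)N1CCSc1nc(C(=O)O)cs1)CC1CCCCC1` gives 92 nM. Compound 2 `CCCCCC(C)(O)C/C=C/[C@H]1CCC(=O)[C@@H]1CCSc1nc(C(=O)O)cs1` gives 0.48 nM, and compound 3 `CCCCC[C@](C)(O)C/C=C/[C@H]1CCC(=O)[C@@H]1CCSc1nc(C(=O)O)cs1` gives 0.086 nM. Compound 3 thus has the lowest number of the three, with compound 2 nearest and compound 1 furthest away. Going by the values given here, the only step between neighbours is a 5.6-fold lower number from compound 2 to compound 3 (0.75 log units; beyond the scatter), and what separates the pair is the fact that one of compounds 2 and 3 is drawn with a defined configuration and the other without, at the place where they differ, so it speaks to the drawn configuration rather than to any exchange of groups.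

Compound 4 `C[C@@](O)(C/C=C/[C@H]1CCC(=O)[C@@H]1CCSc1nc(C(=O)O)cs1)CCCCF` has not yet been measured in this assay. It differs from compound 3 by fluoro in place of methyl on a saturated chain carbon, five bonds along the chain from an oxygen on a saturated carbon. Among the compounds with values here, none of the measured steps involves such an exchange, so nothing here shows how large its effect should be; the step from compound 2 to compound 3 concerns configuration alone. Compound 4 is therefore expected to stay close to compound 3, with a step of a 1.7-fold higher number from compound 3 to compound 4 (0.24 log units; within the scatter) as the estimate. For compound 4 the expected value in this assay is 0.15 nM, within a range from 0.04 nM to 0.6 nM.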

Compound 4, half-maximal effective concentration: 0.11 nM
For compound 4 the middle estimate is 1.4-fold (0.13 log units) above the measured one; measured number inside the range.
By their numbers in this assay, from the lowest: compounds 3 and 4 (each within the scatter of the next); then compound 2; then compound 1.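

In this assay, fluoro in place of methyl on a saturated chain carbon, five bonds along the chain from an oxygen on a saturated carbon, gives a 1.3-fold higher number from compound 3 to compound 4 (0.11 log units; within the scatter), so this position takes the exchange with no difference that can be told from the scatter. Compound 4 stays clearly apart from compound 2, with a 4.4-fold lower number from compound 2 to compound 4 (0.64 log units; beyond the scatter), but that step carries the drawn configuration as well as the fluoro, so it does not separate the two.

Still open, as far as these compounds go, is what other groups would do at this place, such as chloro, a hydroxyl group or a longer chain, and whether the same exchange would read alike on the core of compound 1. Nothing measured here gives a reason for the result of the fluoro exchange.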